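Compound 3 to compound 4: a change on sulfur

The source may report more compounds than this note shows. Statements on the series, on what has been measured and on what is new or still open speak of the compounds shown alone.

In a functional assay on DU-145 cells (Homo sapiens) for inhibition, read by trypan blue exclusion, with a stated time of 96 h (a lower number here means a stronger inhibitor of growth, a higher number a weaker inhibitor of growth), compound 1 `Cc1ccc(S/C(=C/c2sccc2C)C(=O)c2ccc(Cl)cc2)cc1` gives 50000 nM and compound 2 `COc1ccccc1/C=C(/Sc1ccc(C)cc1)C(=O)c1ccc(Cl)cc1` gives 25000 nM. Going by the values given here, the one measured step, a 2.0-fold lower number from compound 1 to compound 2 (0.30 log units; within the scatter), lies within the scatter. It places 2-methoxyphenyl where 3-methylthiophen-2-yl stood on a double-bonded chain carbon, not on the sulfur, so it bears only loosely on what follows.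

Compound 3 `Cc1ccc(CS/C(=C/c2ccc(Cl)cc2)C(=O)c2ccc(Cl)cc2)cc1` reads 10000 nM, the lowest of the three numbers, and its gaps to both other compounds lie beyond the scatter. The next entry is compound 4 `Cc1ccc(S/C(=C/c2ccc(Cl)cc2)C(=O)c2ccc(Cl)cc2)cc1`, with 4-methylphenyl in place of 4-methylbenzyl on a sulfur.

Compound 1, at 50000 nM, and compound 2, at 25000 nM, already carry 4-methylphenyl on the sulfur, and both read higher than compound 3. Among the compounds with values here, each also differs from compound 3 in a second place, so no measured step isolates this change, and the evidence for direction is indirect. In this assay a small step is expected, a 1.8-fold higher number from compound 3 to compound 4 (0.26 log units; within the scatter), with a higher number more likely than a lower one. For compound 4 the estimated value is 18000 nM, with an expected range of 5000 nM to 50000 nM.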

Compound 4, concentration for 50% growth inhibition: 10000 nM
Compound 4: middle estimate off by 1.8-fold (0.26 log units), on the high side; the measured number falls inside the stated range.
By their numbers in this assay, from the lowest: compounds 3 and 4 (each within the scatter of the next); then compounds 2 and 1 (each within the scatter of the next).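

On a sulfur whose other neighbour is the double-bonded chain carbon, 4-methylphenyl and 4-methylbenzyl cannot be told apart in this assay (no change at the digits printed from compound 3 to compound 4 (within the scatter)), so within this pair the position accepts the group with or without the extra carbon. With 4-methylphenyl held on the sulfur, the group on the double-bonded chain carbon now has measurable weight: 4-chlorophenyl in place of 2-methoxyphenyl gives a step beyond the scatter (a 2.5-fold lower number from compound 2 to compound 4 (0.40 log units; beyond the scatter)), and 4-chlorophenyl in place of 3-methylthiophen-2-yl gives another (a 5.0-fold lower number from compound 1 to compound 4 (0.70 log units; beyond the scatter)). The gaps that set compound 3 apart from compounds 1 and 2 therefore follow the group on that carbon in these compounds, not the group on the sulfur, and no measurement here gives a reason for any of these steps.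

Open, as far as these compounds go, is whether a sulfur bearing an amine or a carboxylic acid in place of 4-methylphenyl would read as compounds 3 and 4 do. Going by these compounds alone, also open is whether the steps on the double-bonded chain carbon hold with 4-methylbenzyl on the sulfur, since compound 3 is the only compound here carrying that group.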